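Compound 2 to compound 3: benzyl on the amide nitrogen

A few compounds are considered here, and "the series" means these few. Any claim that something is new, unique, unknown or untested is made for them only; others in the source may bear on it.

Measured in an ADME assay on MT4 cells (Homo sapiens) for cytotoxicity, read by MTT assay, with a stated time of 3 days; a lower number here means that less compound is tolerated, a higher number that more compound is tolerated:
Compound 1 `CC(C)(C)NC(=O)COC(=O)c1ccc([N+](=O)[O-])o1`: > 100000 nM, a limit
Compound 2 `O=C(COC(=O)c1ccc([N+](=O)[O-])o1)NCC1CCCO1`: > 100000 nM, a limit

Compound 2 has no numerical value and stands at the limit of > 100000 nM in this assay, at which 2 of the 2 values shown sit. Compound 3 `O=C(OCC(=O)N(Cc1ccccc1)CC1CCCO1)c1ccc([N+](=O)[O-])o1` carries benzyl in place of hydrogen on an amide-type nitrogen. Among the measured compounds shown here, the only measured step, a step that the two limits leave unreadable from compound 1 to compound 2, has no readable size, so it sets no size for this change. In this assay a modest fall is therefore expected, though compound 3 may well return only a limit too. The expected change is an at least 1.8-fold lower number from compound 2 to compound 3 (0.25 log units; that floor lies within the scatter). Compound 3 is estimated at 55000 nM, with an expected range of 15000 nM to 100000 nM.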

Compound 3, half-maximal cytotoxic concentration: > 100000 nM
Compound 3: only a limit was reported; the forecaster's own chance of this, stated with the estimate: 55%; at least 1.8-fold (0.25 log units) between middle value and limit.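

Compound 2 and compound 3 are both reported only as limits in this assay, so no step can be read between them: the limit of > 100000 nM in this assay, at which 3 of the 3 values shown sit.

The compounds shown leave open the concentration at which any of them becomes cytotoxic, and whether benzyl on the amide-type nitrogen changes it.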